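This account rests on a few compounds, and the source may have more. Where it says the series, first, only, none or still open, it means among the compounds named here.

Compound 3 `O=C(NCN1CCC(c2cccc[n+]2[O-])CC1)c1ccccn1` stands at the top of the three measured numbers in a functional assay on HEK293 cells for agonist activity at D(4) dopamine receptor (Homo sapiens), read by FLIPR (on this read-out higher numbers stand for an effect only at larger amounts of compound and lower numbers for an effect already at smaller amounts), where compound 3 gives 3150 nM. The other two share its core but carry a different group on the carbonyl carbon: compound 1 `O=C(NCN1CCC(c2cccc[n+]2[O-])CC1)c1ccccc1` gives 532 nM and compound 2 `C=Cc1cccc(C(=O)NCN2CCC(c3cccc[n+]3[O-])CC2)c1` gives 68 nM in this assay. Both gaps to compound 3 are beyond the scatter: a 5.9-fold higher number from compound 1 to compound 3 (0.77 log units; beyond the scatter), and a 46-fold higher number from compound 2 to compound 3 (1.67 log units; beyond the scatter). Compound 4 `O=C(NCN1CCC(c2cccc[n+]2[O-])CC1)c1cc(Cl)cc(Cl)c1` has not yet been measured; the change is 3,5-dichlorophenyl in place of pyridin-2-yl on a carbonyl carbon. For the measured compounds named here, two measured steps bear on it. Returning from pyridin-2-yl to a plain phenyl undoes the step of a 5.9-fold higher number from compound 1 to compound 3 (0.77 log units; beyond the scatter), so a lower number is expected. Putting a vinyl group onto that phenyl gave a 7.8-fold lower number from compound 1 to compound 2 (0.89 log units; beyond the scatter), which suggests that a substituted phenyl can reach lower numbers still. A dichlorophenyl is not the same as a vinylphenyl, so the expected step of a 21-fold lower number from compound 3 to compound 4 (1.32 log units; beyond the scatter) is set between these two guides. Compound 4 is therefore expected to give about 150 nM in this assay, with a likely range from 40 nM to 600 nM.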

Compound 4, half-maximal effective concentration: 45 nM
Compound 4: middle estimate off by 3.3-fold (0.52 log units), on the high side, and the stated range covers the measured number.
By their numbers in this assay, from the lowest: compounds 4 and 2 (each within the scatter of the next); then compound 1; then compound 3.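

In this assay the group on this carbonyl carbon moves the number over a wide span, with a 70-fold lower number from compound 3 to compound 4 (1.85 log units; beyond the scatter) as the largest step yet seen at this position. The plain phenyl is passed as well, with a 12-fold lower number from compound 1 to compound 4 (1.07 log units; beyond the scatter) showing that a second substituted phenyl, not only 3-vinylphenyl, gives a lower number than phenyl, while a 1.5-fold lower number from compound 2 to compound 4 (0.18 log units; within the scatter) means that these two substituted phenyls cannot be told apart here. Nothing measured explains why these groups give these numbers.

The compounds shown leave open whether one chlorine alone would give the same step or whether both are needed. They also leave open whether a phenyl carrying an amine or a carboxylic acid would reach this range.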